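A few compounds are considered here, and "the series" means these few. Any claim that something is new, unique, unknown or untested is made for them only; others in the source may bear on it.

Measured compounds:
- compound 1, `CCc1nn2c(C)cc(C)nc2c1Cc1ccc(CCCC2(O)CCN(C(C)C)CC2)cc1`, gives 63 nM in a functional assay on HeLa cells for antagonist activity at G-prodeshotein coupled receptor 4 (Homo sapiens), read by HTRF and cAMP accumulation, with a stated time of 15 min; a lower number here means a stronger inhibitor, a higher number a weaker inhibitor
- compound 2, `CCc1nn2c(C)cc(C)nc2c1Cc1ccc(-c2nnc(N3CCNCC3)o2)cc1`, gives 368 nM in this assay
- compound 3, `CCc1nc2c(C)cc(C)nn2c1Cc1ccc(/C=C/CN2CCN(C(C)C)CC2)cc1`, gives 74 nM in this assay

Compound 1 has the lowest number of the three. Compound 3 sits within the usual scatter of it, so no order can be drawn between those two. Within the data shown here, compound 2 lies beyond the scatter above compound 1, and compound 2 is the one member that carries a piperazine ring with a free ring nitrogen in the side chain.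

Compound 4, `CCc1nn2c(C)cc(C)nc2c1Cc1ccc(CCC(=O)N2CCNCC2)cc1`, is the next step from compound 1. The change is (piperazin-1-yl)carbonyl in place of (4-hydroxy-1-isopropylpiperidin-4-yl)methyl on a saturated chain carbon, two bonds along the chain from an aromatic carbon. Among the measured compounds shown here, no step between measured compounds of this kind is available, so the size of the step has to be judged from the spread of the series. Compound 2 shows that a piperazine-bearing side chain in this shared core gives the weakest number in this assay, and compound 4 carries a piperazine ring as well, now through a carbonyl on a shorter chain. For compound 4 a move to a higher number, beyond the scatter, is expected, with a 4.8-fold higher number from compound 1 to compound 4 (0.68 log units; beyond the scatter). The estimate for compound 4 is 300 nM, with a range from 100 nM to 900 nM.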

Compound 4, half-maximal inhibitory concentration: 53 nM
Compound 4: middle estimate off by 5.7-fold (0.75 log units), on the high side; measured number below the stated range.
By their numbers in this assay, from the lowest: compounds 4, 1 and 3 (each within the scatter of the next); then compound 2.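

In this assay, placing (piperazin-1-yl)carbonyl where (4-hydroxy-1-isopropylpiperidin-4-yl)methyl stood, on a saturated chain carbon, two bonds along the chain from an aromatic carbon, gives a 1.2-fold lower number from compound 1 to compound 4 (0.08 log units; within the scatter), so this position accepts either group without a readable change. The pair shows that neither the hydroxyl nor the isopropyl of the leaving group is required here, and compound 4, with its free piperazine ring nitrogen, gives 53 nM. Nothing measured here explains why the two groups read alike.

The step changes ring, carbonyl and substituents at once, so their separate contributions stay unresolved. Still open, going by these compounds, are a morpholine amide, a 4-isopropylpiperazine amide and a longer chain ahead of the carbonyl, each of which would test a single feature of this change.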